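From Methylamino to Dimethylamino: an Expected Cytotoxicity Limit

The source may hold more compounds than are shown below. What is called first, only, known or untested is meant among the compounds shown, and "the series" means these compounds.

Compound 1 `CNc1cccc(-c2cc(=O)c3cc(N4CCCC4)ccc3[nH]2)c1` has been tested in an ADME assay on Detroit 551 cells (Homo sapiens) for cytotoxicity; a higher number here means a weaker inhibitor, a lower number a stronger inhibitor. In this assay compound 1 gives > 10000 nM, which is a limit of the assay rather than a number. Compound 2 `CCNc1cccc(-c2cc(=O)c3cc(N4CCCC4)ccc3[nH]2)c1` is its closest measured neighbour. In this assay compound 2 gives > 10000 nM, again only a limit. The step that the two limits leave unreadable from compound 1 to compound 2 is therefore unreadable because both values sit at the limit of > 10000 nM in this assay, at which 2 of the 2 values shown sit. Compound 3 `CN(C)c1cccc(-c2cc(=O)c3cc(N4CCCC4)ccc3[nH]2)c1` differs from compound 1 by methyl in place of hydrogen on a nitrogen on an aromatic ring. Within the data shown here, no measured step reads across into this change, so the expected step that the limit leaves unreadable from compound 1 to compound 3 is none beyond the scatter. Compound 3 is estimated at 15000 nM, between 7000 nM and 40000 nM.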

Compound 3, half-maximal inhibitory concentration: > 1000 nM
Compound 3: no number, only a limit; the forecaster's own chance of this, stated with the estimate: 85%; the middle value does not contradict the limit.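

In this assay, among these compounds, compound 3 gives > 1000 nM, a limit and not a number, so no step to it from compound 1 or compound 2 can be read. As far as these compounds go, whether methyl on that nitrogen changes the cytotoxicity of compound 1 stays open.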